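Replacing a Thiazolidinedione Ring With a Carboxymethyl Group

The source may hold more compounds than are shown below. What is called first, only, known or untested is meant among the compounds shown, and "the series" means these compounds.

Measured compounds:
- compound 1 `Cc1cccc(C)c1-c1cccc(OCn2cc(CCC(=O)O)nn2)c1`: 95.6%
- compound 2 `Cc1cccc(C)c1-c1cccc(COc2ccc(CC3SC(=O)NC3=O)s2)c1`: "not determined" (no result reported)

In a functional assay on cells for agonist activity at Free fatty acid receptor 1 (Homo sapiens), read by calcium flux (on this read-out higher numbers stand for larger maximal responses and lower numbers for smaller maximal responses), compound 1 gives 95.6%, a response close to that of the reference. Within the data shown here, compound 2 was run through the same test, but its entry reads "not determined" (no result reported), so compound 2 stands nowhere on the scale in this assay; the only measured point is compound 1.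

The step goes from compound 2 to compound 3 `Cc1cccc(C)c1-c1cccc(COc2ccc(CCC(=O)O)s2)c1`, and the change is carboxymethyl in place of 2,4-dioxo-1,3-thiazolidin-5-yl on a saturated chain carbon bound to an aromatic carbon. Cut one bond further out, the (2,4-dioxo-1,3-thiazolidin-5-yl)methyl end becomes a 2-carboxyethyl chain, which is the same chain that ends compound 1. Among the measured compounds shown here, no step between measured compounds is available, so the size of the change in this assay cannot be taken from a pair already measured. Resting only on compound 1, which gives 95.6% with that 2-carboxyethyl end, compound 3 is expected to reach a large maximal response as well, estimated at 90% with a range from 60% to 110%.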

Compound 3, largest response reached (Emax), in percent of the reference or control that the assay uses: 140%
Compound 3: middle estimate off by 50 percentage points, on the low side; the whole stated range lies below it.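

Compound 2 has no number in this assay, and compound 3, at 140%, has nothing to be set against: no step can be read between them. The compounds shown leave open how far carboxymethyl in place of 2,4-dioxo-1,3-thiazolidin-5-yl changes the maximal response. No further data here bear on this result.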